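Lengthening the chain to the 4-methylpiperazin-1-yl group

This account rests on a few compounds, and the source may have more. Where it says the series, first, only, none or still open, it means among the compounds named here.

The series is followed in an assay on CHO cells for displacement of a labelled ligand from 5-hydroxytryptamine receptor 1D (Homo sapiens); on this read-out lower numbers stand for stronger inhibition and higher numbers for weaker inhibition. Compound 1 `c1coc(CN2CCN(CCCc3c[nH]c4ccc(-n5cnnc5)cc34)CC2)c1` gives 0.4 nM in this assay. Compound 2 `c1cc2[nH]cc(CCCN3CCNCC3)c2cc1-n1cnnc1` gives 31 nM, and compound 3 `CN1CCN(CCCc2c[nH]c3ccc(-n4cnnc4)cc23)CC1` gives 33 nM. Compound 3 therefore carries the highest number of the three measured. Its gap to compound 2 is within the scatter, as a 1.1-fold higher number from compound 2 to compound 3 (0.03 log units; within the scatter) shows, whereas the gap to compound 1 is large, as an 83-fold higher number from compound 1 to compound 3 (1.92 log units; beyond the scatter) shows. The two large steps, a 78-fold higher number from compound 1 to compound 2 (1.89 log units; beyond the scatter) and an 83-fold higher number from compound 1 to compound 3 (1.92 log units; beyond the scatter), both remove the furan-bearing substituent: (furan-2-yl)methyl on an amine nitrogen in a ring in one case, furan-2-yl on a saturated chain carbon bound to an amine nitrogen in a ring in the other. The remaining step is a methyl in place of hydrogen on that ring nitrogen and stays within the scatter.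

Compound 4 `CN1CCN(CCCCc2c[nH]c3ccc(-n4cnnc4)cc23)CC1` differs from compound 3 by (4-methylpiperazin-1-yl)methyl in place of 4-methylpiperazin-1-yl on a saturated chain carbon, three bonds along the chain from an aromatic carbon. Among the compounds with values here, no measured step alters the chain between the core and the ring, so none bears directly on this change; the measured steps only show that the number moves strongly when the furan-bearing substituent is removed, not when the ring nitrogen substituent is varied. With the methyl on the ring nitrogen kept, a small step is expected: compound 4 is expected to give 40 nM in this assay, between 12 nM and 130 nM. This estimate corresponds to an expected 1.2-fold higher number from compound 3 to compound 4 (0.08 log units; within the scatter).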

Compound 4, half-maximal inhibitory concentration: 210 nM
The estimate for compound 4 lay 5.3-fold (0.72 log units) below the measured number; measured number above the stated range.
By their numbers in this assay, from the lowest: compound 1; then compounds 2 and 3 (each within the scatter of the next); then compound 4.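

In this assay the chain that carries the ring does not behave as a neutral spacer: (4-methylpiperazin-1-yl)methyl in place of 4-methylpiperazin-1-yl on a saturated chain carbon, three bonds along the chain from an aromatic carbon, gives a step beyond the scatter (a 6.4-fold higher number from compound 3 to compound 4 (0.80 log units; beyond the scatter)). The step with piperazin-1-yl as the group replaced is of similar size (a 6.8-fold higher number from compound 2 to compound 4 (0.83 log units; beyond the scatter)), so the higher number for compound 4 holds against both compounds with the shorter chain, whereas methyl in place of hydrogen on the ring nitrogen stayed within the scatter. Within the data shown here, this is the first measured change away from the furan-bearing substituent that moves the number beyond the scatter, though both new steps are modest beside the large ones that remove that substituent, and nothing at hand bears on why the number rises with this change.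

Going by these compounds, whether (furan-2-yl)methyl on the ring nitrogen would keep the low number of compound 1 on the longer chain remains open. So does the behaviour of a two-carbon chain, and of a benzyl group on the ring nitrogen in place of (furan-2-yl)methyl.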